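Aryl variation on the hydrazone carbon of the series

The source may hold more compounds than are shown below. What is called first, only, known or untested is meant among the compounds shown, and "the series" means these compounds.

Measured compounds:
compound 1 `CN(C)CCn1cnnc1-c1cc(Oc2ccc(NC(=O)N/N=C/c3c[nH]c4ccccc34)cc2F)ccn1` gives 1630 nM
compound 2 `COc1ccc(/C=N/NC(=O)Nc2ccc(Oc3ccnc(-c4nncn4CCN(C)C)c3)c(F)c2)c(OC)c1` gives 1570 nM
compound 3 `CN(C)CCn1cnnc1-c1cc(Oc2ccc(NC(=O)N/N=C/c3ccccc3)cc2F)ccn1` gives 1780 nM

All three were tested in a functional assay on NCI-H460 cells (Homo sapiens) for cytotoxicity, read by MTT assay, with a stated time of 72 h; a lower number here means a stronger inhibitor, a higher number a weaker inhibitor. Compound 3 carries the highest of the three numbers, yet neither neighbour is separated from it by more than the scatter: the step of a 1.1-fold higher number from compound 1 to compound 3 (0.04 log units; within the scatter) and the step of a 1.1-fold higher number from compound 2 to compound 3 (0.05 log units; within the scatter) are both flat, as is the step of a 1.0-fold lower number from compound 1 to compound 2 (0.02 log units; within the scatter) between the two other aryl variants.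

Compound 4 `COc1cc(/C=N/NC(=O)Nc2ccc(Oc3ccnc(-c4nncn4CCN(C)C)c3)c(F)c2)cc(OC)c1OC` differs from compound 3 only in 3,4,5-trimethoxyphenyl in place of phenyl on a carbon with a double bond to nitrogen. For the measured compounds named here, the step that bears most directly on this change is the one from compound 2 to compound 3, which exchanged a methoxy-bearing phenyl for plain phenyl with no movement beyond the scatter; the exchange of an indolyl group in the steps from compound 1 was equally flat. On that basis no step beyond the scatter is expected in this assay for the further methoxy-bearing ring, in either direction, and the expected step of a 1.0-fold lower number from compound 3 to compound 4 (0.02 log units; within the scatter) is essentially nil. Compound 4 is therefore estimated at 1700 nM, with a range from 850 nM to 3400 nM.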

Compound 4, half-maximal inhibitory concentration: 2770 nM
Beside the measured number, compound 4's estimate is 1.6-fold (0.21 log units) below it; the range from low to high includes it.
By their numbers in this assay, from the lowest: compounds 2, 1, 3 and 4 (each within the scatter of the next).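

In this assay the carbon with a double bond to nitrogen also accommodates 3,4,5-trimethoxyphenyl without a step beyond the scatter: a 1.6-fold higher number from compound 3 to compound 4 (0.19 log units; within the scatter) and a 1.8-fold higher number from compound 2 to compound 4 (0.25 log units; within the scatter) and a 1.7-fold higher number from compound 1 to compound 4 (0.23 log units; within the scatter) are all within it. The flat range at this position therefore now extends from phenyl, with 6 heavy atoms and 0 hydrogen-bond acceptors, to a group with 12 heavy atoms and 3 hydrogen-bond acceptors. No supporting evidence is available to interpret these small differences.

Going by these compounds, all four compounds carry an aromatic ring at this position, so it remains open whether a straight alkyl chain or a cyclohexyl group would leave the number as flat. Also open, on these data alone, is the effect of a ring bearing a carboxylic acid or a primary amine.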